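Dropping a methyl from the core of compound 2

This account rests on a few compounds, and the source may have more. Where it says the series, first, only, none or still open, it means among the compounds named here.

In a functional assay on cells (Cancer cell lines, Homo sapiens) for inhibition (on this read-out lower numbers stand for stronger inhibition of growth and higher numbers for weaker inhibition of growth), compound 1 `Cc1cc(-c2nc3sc(C)cn3c2/C=N/NC(=N)N)c(C)s1` gives 33100 nM and compound 2 `Cc1cn2c(/C=N/NC(=N)N)c(-c3ccsc3)nc2s1` gives 27500 nM, so compound 2 stands level with compound 1, within the scatter. Compound 3 `N=C(N)N/N=C/c1c(-c2ccsc2)nc2sccn12` differs from compound 2 by hydrogen in place of methyl on an aromatic carbon. For the measured compounds named here, the one measured step, a 1.2-fold lower number from compound 1 to compound 2 (0.08 log units; within the scatter), is thiophen-3-yl in place of 2,5-dimethylthiophen-3-yl. It also loses methyl groups, at a different place, and lies within the scatter. No change beyond the scatter is therefore expected, and the expected step is a 1.0-fold higher number from compound 2 to compound 3 (0.01 log units; within the scatter). For compound 3 the estimated value is 28000 nM, with an expected range of 15000 nM to 50000 nM.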

Compound 3, concentration for total growth inhibition: 31600 nM
Beside the measured number, compound 3's estimate is 1.1-fold (0.05 log units) below it, and the stated range covers the measured number.
By their numbers in this assay, from the lowest: compounds 2, 3 and 1 (each within the scatter of the next).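

Hydrogen in place of methyl on an aromatic carbon next to the ring sulfur gives a 1.1-fold higher number from compound 2 to compound 3 (0.06 log units; within the scatter) in this assay and so shows that this methyl on the core, a place the earlier thiophen-3-yl step left untouched, can be lost without a change beyond the scatter. Still open, from the compounds shown here alone, is whether a different group at this carbon, such as an amine, a carboxylic acid or a longer chain, would move the number beyond the scatter. No measured evidence bears on this result.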